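Bromophenyl placement on the ring amine nitrogen

The source may hold more compounds than are shown below. What is called first, only, known or untested is meant among the compounds shown, and "the series" means these compounds.

Values in an assay on CHO cells for displacement of a labelled ligand from adenosine receptor A1 (Homo sapiens), read by scintillation counting, with a stated time of 90 min, tested at 1 uM, in the presence of a further agent that is not named here; on this read-out lower numbers stand for less inhibition and higher numbers for more inhibition at the one concentration tested (going by the name of the read-out):
compound 1 `CCCn1c(=O)[nH]c2nc(-c3ccc(S(=O)(=O)N4CCN(c5cccc(Br)c5)CC4)cc3)[nH]c2c1=O`, -1%
compound 2 `CCCn1c(=O)[nH]c2nc(-c3ccc(S(=O)(=O)N4CCN(Cc5ccc(Br)cc5)CC4)cc3)[nH]c2c1=O`, 31%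
compound 3 `CCCn1c(=O)[nH]c2nc(-c3ccc(S(=O)(=O)N4CCN(c5ccccc5Br)CC4)cc3)[nH]c2c1=O`, 28%

Compound 1 stands lowest of the three numbers in this assay; both other compounds lie beyond the scatter above it. Compound 4 `CCCn1c(=O)[nH]c2nc(-c3ccc(S(=O)(=O)N4CCN(c5ccc(Br)cc5)CC4)cc3)[nH]c2c1=O` is not yet measured. It differs from compound 1 by 4-bromophenyl in place of 3-bromophenyl on an amine nitrogen in a ring. The two steps that bear on this are a number 32 percentage points higher from compound 1 to compound 2 (beyond the scatter) and a number 29 percentage points higher from compound 1 to compound 3 (beyond the scatter): each replaces the 3-bromophenyl of compound 1 and each gives a higher number. For the measured compounds named here, no measured step moves the bromine to the 4-position on a phenyl directly on the ring nitrogen, so the size is uncertain, but an increase beyond the scatter is expected, roughly a number 23 percentage points higher from compound 1 to compound 4 (beyond the scatter). Compound 4 is therefore estimated at 22%, with a range of -5% to 45% in this assay.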

Compound 4, a percentage reported as inhibition, at one concentration (the size of the read-out at that concentration, not a potency): 13%
Beside the measured number, compound 4's estimate is 9 percentage points above it; measured number inside the range.
By their numbers in this assay, from the lowest: compound 1; then compound 4; then compounds 3 and 2 (each within the scatter of the next).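

The position of the bromine on the phenyl now reads as a graded effect rather than a simple contrast in this assay: a number 14 percentage points higher from compound 1 to compound 4 (beyond the scatter) and a number 15 percentage points lower from compound 3 to compound 4 (beyond the scatter), which places the 4-bromophenyl apart from both other phenyl isomers. Keeping the bromine in the 4-position does not make the phenyl and benzyl groups equivalent, with a number 18 percentage points lower from compound 2 to compound 4 (beyond the scatter). The link to the ring nitrogen therefore matters as well as the bromine position.

From the compounds shown here alone, whether an amine or a carboxylic acid in place of the bromine, or a longer chain in place of the benzyl link, would shift these numbers stays open. No available evidence accounts for this order among the compounds.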